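Dichlorobenzyl cinnamate glycolamides: cytotoxicity notes

This account rests on a few compounds, and the source may have more. Where it says the series, first, only, none or still open, it means among the compounds named here.

Measured in a functional assay on HeLa cells (Homo sapiens) for cytotoxicity, read by MTT assay, with a stated time of 72 h; on this read-out lower numbers stand for stronger inhibition and higher numbers for weaker inhibition:
compound 1 `COc1ccc(NC(=O)COC(=O)/C=C/c2cc(OC)c(OCc3ccc(Cl)c(Cl)c3)c(OC)c2)cc1`: compound 1 gives > 200000 nM, a limit of the assay.
compound 2 `COc1cc(/C=C/C(=O)OCC(=O)Nc2ccc(Cl)cc2)cc(OC)c1OCc1ccc(Cl)c(Cl)c1`: compound 2 gives > 200000 nM, a limit of the assay.
compound 3 `O=C(COC(=O)/C=C/c1ccc(O)c(O)c1)Nc1ccc(Cl)cc1`: compound 3 gives 195000 nM.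

Compound 2 and compound 3 share the glycolamide cinnamate framework; how their cores differ is not broken down here. Within the core of compound 2, the change methoxy in place of chloro on an aromatic carbon gives a step that the two limits leave unreadable from compound 2 to compound 1, because of the limit of > 200000 nM in this assay, at which 2 of the 3 values shown sit.

Compound 4 `COc1ccc(NC(=O)COC(=O)/C=C/c2ccc(O)c(O)c2)cc1` carries the same change on the core of compound 3: methoxy in place of chloro on an aromatic carbon. The measured step from compound 2 to compound 1 is unreadable, so it offers no size to carry over. Compound 3 sits close to the assay limit, and compound 4 is therefore expected to stay near it, the estimated step being a 1.3-fold higher number from compound 3 to compound 4 (0.11 log units; within the scatter). For compound 4 the estimate in this assay is 250000 nM, with a range from 90000 nM to 700000 nM; a reported limit rather than a number is quite likely.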

Compound 4, half-maximal inhibitory concentration: > 200000 nM
Compound 4 ended at the assay's limit; the forecaster's own chance of this, stated with the estimate: 60%; the middle value does not contradict the limit.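

In this assay, methoxy in place of chloro on the core of compound 3 gives an at least 1.0-fold higher number from compound 3 to compound 4 (0.01 log units; that floor lies within the scatter). For the compounds shown here, the matching step on the other core cannot be read, so the two cores offer no pair of sizes to compare: the limit of > 200000 nM in this assay, at which 3 of the 4 values shown sit. The change has thus been tried on both cores without yielding a measured size on either, and whether its effect carries from one core to the other remains unknown.

The compounds shown leave open whether an amine or a carboxylic acid in place of chloro on this aromatic carbon would give a value clear of the limit. The same question stands for a longer alkoxy chain in place of methoxy.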